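This account rests on a few compounds, and the source may have more. Where it says the series, first, only, none or still open, it means among the compounds named here.

Compound 1 `CC(C)(C)ONC(=N)c1ccc2[nH]c(-c3cccc(-c4ccccc4O)c3O)cc2c1` is measured in a physicochemical assay for solubility, in phosphate buffer, at pH 7.4; on this read-out higher numbers stand for higher solubility and lower numbers for lower solubility; there compound 1 gives < 10000 nM, which is a limit of the assay rather than a number. For the measured compounds named here, compound 2 `N/C(=N/C(=O)OCC(Cl)(Cl)Cl)c1ccc2[nH]c(-c3cccc(-c4ccccc4O)c3O)cc2c1` is the single measured neighbour. In this assay compound 2 gives < 10000 nM, again a limit. Going by the values given here, the one measured step, a step that the two limits leave unreadable from compound 1 to compound 2, therefore has no readable size. Compound 3 `CC(=O)OC(C)OC(=O)NC(=N)c1ccc2[nH]c(-c3cccc(-c4ccccc4O)c3O)cc2c1` carries (1-acetoxyethoxy)carbonyl in place of tert-butoxy on an amine nitrogen. Among the compounds with values here, both measured values sit at the limit of < 10000 nM in this assay, at which 2 of the 2 values shown sit, so no measured step gives a size or direction for this change; the step that the limit leaves unreadable from compound 1 to compound 3 is expected to keep compound 3 near that limit. Compound 3 is estimated at 5000 nM, between 1000 nM and 20000 nM.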

Compound 3, solubility: < 10000 nM
Compound 3: a limit, no number; the forecaster's own chance of this, stated with the estimate: 70%; the middle value is on the limit's open side.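

In this assay compound 3 gives < 10000 nM, a limit and not a number. For the compounds shown here, no step can therefore be read from compound 1 to compound 3. The compounds shown leave open whether their solubilities differ at all, as all share one reading: the limit of < 10000 nM in this assay, at which 3 of the 3 values shown sit.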